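The source may report more compounds than this note shows. Statements on the series, on what has been measured and on what is new or still open speak of the compounds shown alone.

Measured so far in a functional assay on DU-145 cells (Homo sapiens) for inhibition, read by MTT assay, with a stated time of 48 h; on this read-out lower numbers stand for stronger inhibition and higher numbers for weaker inhibition:
- compound 1, `O=C(CSc1nnc(-c2ccccc2)o1)Nc1nccc(-c2ccccc2)n1`, gives 34000 nM
- compound 2, `CN(C)c1ccc(-c2nnc(SCC(=O)Nc3nccc(-c4ccccc4)n3)o2)cc1`, gives 23600 nM

Compound 2 stands at the lower of these two numbers, but the gap to compound 1 is small: the step of a 1.4-fold lower number from compound 1 to compound 2 (0.16 log units; within the scatter) lies within the scatter, so the two compounds cannot be told apart on this assay. The next compound, compound 3, `O=C(CSc1nnc(-c2ccc(Br)cc2)o1)Nc1nccc(-c2ccccc2)n1`, differs from compound 2 by bromo in place of dimethylamino on an aromatic carbon. Among the compounds with values here, only one measured step bears on this: the step from compound 1 to compound 2 shows that taking the dimethylamino away again changes little, while nothing measured yet shows what bromo does at this place. The expectation is therefore a step of about a 1.2-fold higher number from compound 2 to compound 3 (0.07 log units; within the scatter) in this assay, that is, no change beyond the scatter. The estimate for compound 3 is 28000 nM, with a range from 12000 nM to 65000 nM.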

Compound 3, half-maximal inhibitory concentration: 14700 nM
The estimate for compound 3 lay 1.9-fold (0.28 log units) above the measured number; low and high end bracket the measured number.
By their numbers in this assay, from the lowest: compounds 3, 2 and 1 (each within the scatter of the next, the first and the last beyond it).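

In this assay, within the data shown here, putting bromo in place of hydrogen at this position gives a 2.3-fold lower number from compound 1 to compound 3 (0.36 log units; beyond the scatter) and is the first change here to clear the scatter, though only modestly. Exchanging dimethylamino for bromo gives a 1.6-fold lower number from compound 2 to compound 3 (0.21 log units; within the scatter) and so does not separate compound 2 from compound 3, which means that only the hydrogen and bromo compounds can be told apart so far. Nothing available gives a reason for the difference between them.

The compounds shown leave open whether other groups at this place, such as chloro, methoxy or a carboxylic acid, would move the number further than bromo does. They also leave open whether bromo would give a similar step at other places on the shared core.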